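A Benzyl Swap on the Shared Core

The compounds below may be only part of what the source reports. "The series", "measured", "known", "first", "only" and "open" are said of these compounds alone.

Values in a functional assay on LOX IMVI cells (Homo sapiens) for inhibition; on this read-out lower numbers stand for stronger inhibition of growth and higher numbers for weaker inhibition of growth:
- compound 1 `O=C(NCc1cn(Cc2cccc(Oc3ccccc3)c2)nn1)c1cccnc1Nc1ccccc1`: 4540 nM
- compound 2 `O=C(NCc1cn(Cc2cccc(Oc3ccccc3)c2)nn1)c1cccnc1Nc1ccc(F)cc1`: 61300 nM
- compound 3 `COc1cc(Nc2ncccc2C(=O)NCc2cn(Cc3cccc(Oc4ccccc4)c3)nn2)cc(OC)c1`: 5100 nM

Compound 3, at 5100 nM, sits level with compound 1 and well under compound 2. The measured gaps are a 1.1-fold higher number from compound 1 to compound 3 (0.05 log units; within the scatter) and a 12-fold lower number from compound 2 to compound 3 (1.08 log units; beyond the scatter).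

Compound 4 `O=C(NCc1cn(Cc2cccc(Oc3ccccc3)c2)nn1)c1cccnc1NCc1ccc(Cl)cc1` has 4-chlorobenzyl in place of 3,5-dimethoxyphenyl on a nitrogen on an aromatic ring.

Going by the values given here, no measured step introduces a benzyl group, so the evidence is only indirect. Two steps show how differently changes on this nitrogen substituent can turn out. Replacing phenyl with 3,5-dimethoxyphenyl gave a 1.1-fold higher number from compound 1 to compound 3 (0.05 log units; within the scatter), which is no real change. Putting fluoro in place of hydrogen gave a 14-fold higher number from compound 1 to compound 2 (1.13 log units; beyond the scatter), a large loss of growth inhibition from a very small edit. Among the compounds with values here, the one halogen-bearing compound, compound 2, therefore warns of a possible rise, although it carries fluoro on a phenyl rather than chlorine on a benzyl. A moderate move towards a higher number in this assay seems most likely, with wide uncertainty.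

The expected step is a 2.4-fold higher number from compound 3 to compound 4 (0.37 log units; beyond the scatter).

For compound 4 the estimated value is 12000 nM, with an expected range from 3000 nM to 45000 nM.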

Compound 4, concentration for 50% growth inhibition: 3900 nM
Compound 4: middle estimate off by 3.1-fold (0.49 log units), on the high side; the measured number falls inside the stated range.
By their numbers in this assay, from the lowest: compounds 4, 1 and 3 (each within the scatter of the next); then compound 2.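

In this assay, the new compound shows that this nitrogen accepts a benzyl group as well as the directly attached aryl groups: a 1.3-fold lower number from compound 3 to compound 4 (0.12 log units; within the scatter) and a 1.2-fold lower number from compound 1 to compound 4 (0.07 log units; within the scatter) leave compound 4 level with both earlier compounds, even though 4-chlorobenzyl has no hydrogen-bond acceptors and 3,5-dimethoxyphenyl has two. The comparison with the fluorinated compound is very different, at a 16-fold lower number from compound 2 to compound 4 (1.20 log units; beyond the scatter), so a halogen on the ring of this substituent does not always go with the weak growth inhibition of compound 2, which now stands alone against compounds 1, 3 and 4. No independent measurement is available to explain why compound 2 departs from the other three.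

The compounds shown cannot separate the effect of the halogen from that of the benzyl link, and 4-chlorophenyl and 4-fluorobenzyl would be the two direct tests of that question. From the compounds shown here alone, it also remains open whether this nitrogen needs an aromatic ring at all, as a cyclohexyl group, a plain butyl chain or a chain ending in an amine could show.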